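Removing the dimethylamino group from compound 1

The compounds below may be only part of what the source reports. "The series", "measured", "known", "first", "only" and "open" are said of these compounds alone.

Compound 1 `CN(C)Cc1csc(NC(=O)c2cc(C(C)(C)C)nn2Cc2ccccc2)n1`: > 100 ug/mL
Compound 2 `NCc1csc(NC(=O)c2cc3ccccc3o2)n1`: > 100 ug/mL

In a physicochemical assay for solubility, read by nephelometry, measured as kinetic solubility, at pH 2.0 (a lower number here means a less soluble compound, a higher number a more soluble compound), compound 1 gives > 100 ug/mL, which is a limit of the assay and not a number. Compound 2 gives > 100 ug/mL, also a limit. Compound 1 therefore stands at the limit of > 100 ug/mL in this assay, at which 2 of the 2 values shown sit. Compound 3 `Cc1csc(NC(=O)c2cc(C(C)(C)C)nn2Cc2ccccc2)n1` keeps the core of compound 1 and differs by hydrogen in place of dimethylamino on a saturated chain carbon bound to an aromatic carbon, turning (dimethylamino)methyl into methyl. Within the data shown here, no measured pair shows this change. A clear fall is expected an at least 6.6-fold lower number from compound 1 to compound 3 (0.82 log units; beyond the scatter), beyond the usual scatter of this assay. Compound 3 is estimated at 15 ug/mL, with an expected range of 3 ug/mL to 70 ug/mL.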

Compound 3, solubility: < 1.6 ug/mL
Compound 3 ended at the assay's limit; the forecaster's own chance of this, stated with the estimate: 20%; middle value at least 9.3-fold (0.97 log units) away from the limit.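

In this assay, among these compounds, compound 3 gives < 1.6 ug/mL, a limit of the assay and the first value at this end of its range. Hydrogen in place of dimethylamino on a saturated chain carbon bound to an aromatic carbon gives an at least 62-fold lower number from compound 1 to compound 3 (1.79 log units; beyond the scatter), a large step whose exact size cannot be read. Among the compounds shown here, compound 1 and compound 2 share one limit and alone showed no step at this position.

The compounds shown leave open whether a morpholine, a carboxylic acid or a longer chain bearing an amine in this place would keep the reading at the upper limit or let it fall.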